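Swapping the dienyl amide of compound 2 for a bromoethyl amide

A few compounds are considered here, and "the series" means these few. Any claim that something is new, unique, unknown or untested is made for them only; others in the source may bear on it.

Measured so far:
- compound 1, `C/C=C/C(=O)N(Cc1cc(OC)c(OC)c(OC)c1)c1ccc(OC)c(O)c1`: 9160 nM
- compound 2, `C/C=C/C=C/C(=O)N(Cc1ccc(OC)c(O)c1)c1cc(OC)c(OC)c(OC)c1`: 180 nM

In a functional assay on KYSE-450 cells (Homo sapiens) for inhibition, read by MTT assay, with a stated time of 48 h (on this read-out lower numbers stand for stronger inhibition and higher numbers for weaker inhibition), compound 2 gives 180 nM, the lower of the two numbers shown; compound 1 gives 9160 nM, and the gap between the two lies beyond the usual scatter. Going by the values given here, compounds 1 and 2 differ in more than one place, so their two values show only that compound 2 is the stronger inhibitor of the pair.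

Compound 3, `COc1ccc(CN(C(=O)C(C)Br)c2cc(OC)c(OC)c(OC)c2)cc1O`, differs from compound 2 in a single place: 1-bromoethyl in place of penta-1,3-dien-1-yl on a carbonyl carbon. Among the compounds with values here, no measured pair shows this change, so its effect is unknown from the data. A clear step is expected in this assay, towards a higher number, rather than one within the scatter. The estimate for compound 3 is 1500 nM, with a range from 300 nM to 8000 nM, corresponding to an expected step of an 8.3-fold higher number from compound 2 to compound 3 (0.92 log units; beyond the scatter).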

Compound 3, half-maximal inhibitory concentration: 160 nM
Estimate against measurement, compound 3: 9.4-fold (0.97 log units) above; the measured number lies below the stated range.
By their numbers in this assay, from the lowest: compounds 3 and 2 (each within the scatter of the next); then compound 1.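

In this assay, placing 1-bromoethyl instead of penta-1,3-dien-1-yl on the carbonyl carbon gives a 1.1-fold lower number from compound 2 to compound 3 (0.05 log units; within the scatter), so the two compounds cannot be told apart on this read-out. Going by these compounds alone, this is the first comparison here that changes only one place, and it shows that, in this pair, the 2 double bonds of penta-1,3-dien-1-yl are not required for a value in this range: a group of 3 heavy atoms, one of them bromine, serves as well as one of 5 carbons. Nothing measured here explains why the two groups match.

Still open, on these data alone, is whether the bromine itself matters, which a plain ethyl group or a 1-chloroethyl group on the same carbonyl carbon would test. It is also unknown how far this position tolerates change, for example a longer chain or a chain ending in an amine or a carboxylic acid.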